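Amide analogues of a dimethoxy tetralin acetic acid

A few compounds are considered here, and "the series" means these few. Any claim that something is new, unique, unknown or untested is made for them only; others in the source may bear on it.

Compound 1 `COc1cc2c(cc1OC)C(CC(=O)O)CC2` gives 23.9% in a functional assay on the whole organism (strain Wistar) for inhibition, with Rattus norvegicus as the target, read by paw edema, with stated times of 60 min and 4 h, at a dose of 100 mg/kg by the oral route; on this read-out lower numbers stand for less inhibition and higher numbers for more inhibition at the one dose given (going by the name of the read-out).
Compound 2 `CCCCCCNC(=O)CC1CCc2cc(OC)c(OC)cc21` gives 42.1% in this assay.
Compound 3 `COc1cc2c(cc1OC)C(CC(=O)NC1CCCC1)CC2` gives 45.3% in this assay.

Compound 1 stands lowest of the three numbers shown in this assay; compound 2 is its nearest neighbour, and compound 3 the furthest. The step considered here leads from compound 1 to compound 4 `COc1cc2c(cc1OC)C(CC(=O)N1CCCC1)CC2`, which has not yet been measured in this assay. The change is pyrrolidin-1-yl in place of hydroxy on a carbonyl carbon.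

Going by the values given here, two measured steps bear on this change, since both replace the same hydroxy on the carbonyl carbon with a nitrogen-linked group: a number 18.2 percentage points higher from compound 1 to compound 2 (beyond the scatter) and a number 21.4 percentage points higher from compound 1 to compound 3 (beyond the scatter). Both lie beyond the scatter and in the same direction, while the pair of compounds 2 and 3 differ from each other only within the scatter (a number 3.2 percentage points higher from compound 2 to compound 3 (within the scatter)). On this basis a rise of similar size is expected for compound 4, that is a number 16.1 percentage points higher from compound 1 to compound 4 (beyond the scatter). Compound 4 is therefore estimated to give 40% in this assay, with a range from 28% to 52%.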

Compound 4, a percentage reported as inhibition, in the whole organism at one dose (the size of the read-out at that dose, not a potency): 24.2%
Compound 4: the middle estimate sits 15.8 percentage points above what was measured; the whole stated range lies above it.
By their numbers in this assay, from the lowest: compounds 1 and 4 (each within the scatter of the next); then compounds 2 and 3 (each within the scatter of the next).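

In this assay, a nitrogen-linked group on the carbonyl carbon does not by itself bring a rise, since pyrrolidin-1-yl in place of hydroxy gives a number 0.3 percentage points higher from compound 1 to compound 4 (within the scatter). What sits on the nitrogen therefore decides the outcome at this position, with a number 21.1 percentage points lower from compound 3 to compound 4 (beyond the scatter) and a number 17.9 percentage points lower from compound 2 to compound 4 (beyond the scatter). Compound 4 lacks the amide hydrogen that compounds 2 and 3 keep, but no measurement here links that difference to the lower number, and nothing available explains the result.

On these data alone, whether the missing amide hydrogen or the ring closed through the nitrogen matters more remains open, and an open-chain diethylamino group on the same carbonyl carbon would help to separate the two. Whether piperidin-1-yl or morpholin-4-yl would stay with compound 4 or join compounds 2 and 3 is also unresolved.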